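This account rests on a few compounds, and the source may have more. Where it says the series, first, only, none or still open, it means among the compounds named here.

Measured so far in a functional assay on WiDr cells (Homo sapiens) for inhibition; on this read-out lower numbers stand for stronger inhibition and higher numbers for weaker inhibition:
- compound 1 `CCCCNC(=O)N1CC1C#N`: 14000 nM
- compound 2 `N#CC1CN1C(=O)Nc1ccc(F)cc1`: 2100 nM
- compound 3 `CC(C)(C)NC(=O)N1CC1C#N`: 180000 nM

Compound 3 gives the highest number of the three, so it is the weakest inhibitor here. The next compound, compound 4 `N#CC1CN1C(N)=O`, differs from it by hydrogen in place of tert-butyl on an amide-type nitrogen. Among the measured compounds shown here, only one measured step speaks to this place: a 13-fold higher number from compound 1 to compound 3 (1.11 log units; beyond the scatter), where the bulkier branched group raised the number sharply. Taking the group away altogether is not the same change, so the direction is uncertain, but a drop back toward the level of compound 1 seems the likelier outcome. The expected step is a 4.5-fold lower number from compound 3 to compound 4 (0.65 log units; beyond the scatter) in this assay. Compound 4 is therefore estimated at 40000 nM, with a range from 6000 nM to 250000 nM.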

Compound 4, half-maximal inhibitory concentration: > 280000 nM
Compound 4: only a limit was reported (the forecaster's own chance of this, stated with the estimate: 15%); middle value at least 7.0-fold (0.84 log units) away from the limit.
By their numbers in this assay, from the lowest: compound 2; then compound 1; then compound 3. At a limit, above all of these: compound 4.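

In this assay compound 4 gives > 280000 nM as a limit and not as a number. Hydrogen on the amide-type nitrogen falls well short of butyl, with an at least 20-fold higher number from compound 1 to compound 4 (1.30 log units; beyond the scatter) as the smallest possible change, so removing the group entirely does not recover what tert-butyl lost. The floor of an at least 1.5-fold higher number from compound 3 to compound 4 (0.19 log units; that floor lies within the scatter) does not put hydrogen and tert-butyl in any order. Still open, going by these compounds, is how a longer chain such as hexyl, or a chain ending in an amine, would read on this nitrogen.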